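Amino for fluoro on the fused ring: expectation for compound 3

The source may hold more compounds than are shown below. What is called first, only, known or untested is meant among the compounds shown, and "the series" means these compounds.

Compound 2 `Cc1ncccc1-c1cnc(NCc2c(F)cc(F)c3c2CCO3)n2cnnc12` in an assay on isolated protein for binding affinity to Polycomb protein EED (Homo sapiens), read by surface plasmon resonance (a higher number here means weaker binding, a lower number tighter binding), gives 1200 nM. Compound 1 `Cc1ncccc1-c1cnc(NCc2c(F)cc(Cl)c3c2CCO3)n2cnnc12`, the chloro analogue, gives 2400 nM in this assay; the pair differ by a 2.0-fold lower number from compound 1 to compound 2 (0.30 log units; within the scatter), so the two numbers are not separable. Compound 3 `Cc1ncccc1-c1cnc(NCc2c(F)cc(N)c3c2CCO3)n2cnnc12` is not yet measured. It differs from compound 2 in amino in place of fluoro on an aromatic carbon. Among the compounds with values here, no measured step exchanges a halogen for an amino group; the only step seen, the fluoro for chloro exchange, came to a 2.0-fold lower number from compound 1 to compound 2 (0.30 log units; within the scatter) and gives no direct guide to a change that brings in a hydrogen-bond donor and a hydrogen-bond acceptor. With nothing in the pair pointing either way, no step beyond the scatter is expected for compound 3, and the range is kept wide. Compound 3 is therefore estimated at 1200 nM in this assay, with a range of 350 nM to 4000 nM, which means an expected step of no change at the digits printed from compound 2 to compound 3 (within the scatter).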

Compound 3, dissociation constant in the Polycomb protein EED assay: 500 nM
Compound 3: the middle estimate sits 2.4-fold (0.38 log units) above what was measured, within the range that was stated.
By their numbers in the Polycomb protein EED assay, from the lowest: compound 3; then compounds 2 and 1 (each within the scatter of the next).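

Within the data shown here, in the Polycomb protein EED assay, amino in place of fluoro on this aromatic carbon gives a 2.4-fold lower number from compound 2 to compound 3 (0.38 log units; beyond the scatter), and amino in place of chloro gives a 4.8-fold lower number from compound 1 to compound 3 (0.68 log units; beyond the scatter); these are the only steps among the three compounds that lie beyond the scatter. The position therefore responds to the group placed on it, which the halogen pair could not show, since its step stays within the scatter: a 2.0-fold lower number from compound 1 to compound 2 (0.30 log units; within the scatter). In a physicochemical assay for solubility, in phosphate buffer, with a stated time of 24 h, at pH 7.4 (on this read-out higher numbers stand for higher solubility and lower numbers for lower solubility), compound 2 gives 4000 nM and compound 3 gives 69000 nM. The exchange of fluoro for amino also goes with higher solubility, so tighter binding and higher solubility arrive together in this pair: the measured solubility of compound 2, 4000 nM, and of compound 3, 69000 nM, a 17-fold higher number (1.24 log units; beyond the scatter)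

The compounds shown do not tell whether the tighter binding depends on the hydrogen-bond donor that amino brings in. A hydroxyl, methoxy or dimethylamino group on this carbon would bear on that question, and on whether the solubility gain is tied to amino itself.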